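Methoxy Substitution on a Shared Core and Antiproliferative Potency

This account rests on a few compounds, and the source may have more. Where it says the series, first, only, none or still open, it means among the compounds named here.

Compound 1 `Fc1ccc(/C=C/c2cc3ccccc3nc2Cl)cc1` was tested in a functional assay on MDA-MB-231 cells (Homo sapiens) for antiproliferative activity, read by sulforhodamine B assay, with a stated time of 72 h; on this read-out higher numbers stand for weaker inhibition and lower numbers for stronger inhibition. In this assay compound 1 reaches only a limit, > 50000 nM, rather than a number. Compound 2 `COc1ccc2nc(Cl)c(/C=C/c3ccc(F)cc3)cc2c1` differs from it by methoxy in place of hydrogen on an aromatic carbon and gives 11000 nM in this assay. The step of an at least 4.5-fold lower number from compound 1 to compound 2 (0.65 log units; beyond the scatter) is stated as a lower bound, since one of the values shown sits at the limit of > 50000 nM in this assay, at which 1 of the 3 values shown sits.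

Compound 3 `FC(F)(F)c1ccc(/C=C\c2cc3ccccc3nc2Cl)c(C(F)(F)F)c1` carries a different core from compound 1, and the difference between the two cores is not broken down here. In this assay compound 3 gives 41800 nM.

Compound 4 `COc1ccc2nc(Cl)c(/C=C\c3ccc(C(F)(F)F)cc3C(F)(F)F)cc2c1` stands to compound 3 as compound 2 stands to compound 1: the change is methoxy in place of hydrogen on an aromatic carbon, the same change at the same place. Compound 4 has not been measured in this assay. Resting on the step from compound 1 to compound 2, an at least 4.5-fold lower number from compound 1 to compound 2 (0.65 log units; beyond the scatter), a step of a 4.2-fold lower number from compound 3 to compound 4 (0.62 log units; beyond the scatter) is expected. The estimate for compound 4 in this assay is therefore 10000 nM, expected to fall between 4000 nM and 30000 nM.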

Compound 4, half-maximal inhibitory concentration: > 50000 nM
Compound 4: only a limit was reported; the forecaster's own chance of this, stated with the estimate: 5%; at least 5.0-fold (0.69 log units) between middle value and limit.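

In this assay compound 4 reaches only a limit, > 50000 nM. The methoxy change therefore did not carry from the core of compound 1 to the core of compound 3: the new step, an at least 1.1-fold higher number from compound 3 to compound 4 (0.07 log units; that floor lies within the scatter), stands apart from the earlier one, and the gap lies beyond the scatter: the same change on two cores in this assay, an at least 4.5-fold lower number (0.65 log units; beyond the scatter) from compound 1 to compound 2 and an at least 1.1-fold higher number (0.07 log units; that floor lies within the scatter) from compound 3 to compound 4, at least 5.4-fold (0.73 log units) apart, beyond the scatter of two such steps This does not show that methoxy weakens inhibition on the core of compound 3, since the floor of the new step lies within the scatter, and with both steps resting on a limit, neither their true sizes nor the reason they part can be read, nor how the change would behave on a third core: the limit of > 50000 nM in this assay, at which 2 of the 4 values shown sit.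

The compounds shown leave open which part of the difference between the two cores decides the outcome. They also leave open whether an amine or a carboxylic acid in place of the methoxy would give a number rather than a limit in this assay.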